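The compounds below may be only part of what the source reports. "The series", "measured", "known", "first", "only" and "open" are said of these compounds alone.

Measured so far in a functional assay on HeLa cells (Homo sapiens) for inhibition, read by CCK-8 assay, with a stated time of 48 h; on this read-out lower numbers stand for stronger inhibition and higher numbers for weaker inhibition:

Compound 1 `COc1cc(-c2ccnc3cc(-c4ccc(Cl)cc4)nn23)cc(OC)c1OC`: 1490 nM
Compound 2 `COc1cc(-c2ccnc3cc(-c4ccc(C)cc4)nn23)cc(OC)c1OC`: 21 nM
Compound 3 `C=Cc1ccc(-c2cc3nccc(-c4cc(OC)c(OC)c(OC)c4)n3n2)cc1`: 882 nM

These three compounds share a core and differ in one group only. Compound 3 sits level with compound 1, as a 1.7-fold lower number from compound 1 to compound 3 (0.23 log units; within the scatter) shows. It lies far from compound 2, as a 42-fold higher number from compound 2 to compound 3 (1.62 log units; beyond the scatter) shows.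

The next compound is compound 4 `CCOC(=O)c1ccc(-c2cc3nccc(-c4cc(OC)c(OC)c(OC)c4)n3n2)cc1`, which has ethoxycarbonyl in place of vinyl on an aromatic carbon, para to a large group: ethoxycarbonyl in place of vinyl on an aromatic carbon.

All three measured steps involve this same place, but none involves ethoxycarbonyl, so the data give no direct measure of this group. Two of the steps are large, and both involve methyl: one is a 71-fold lower number from compound 1 to compound 2 (1.85 log units; beyond the scatter), and the other is the step to compound 3 given above. Among the compounds with values here, the chloro and vinyl compounds show no difference beyond the scatter, so methyl is the only group here that goes with a low number. On that basis, compound 4 is expected to resemble compound 3 rather than compound 2 in this assay. The expected step is a 1.7-fold higher number from compound 3 to compound 4 (0.23 log units; within the scatter), which is no clear change. The range stays wide, since a 71-fold lower number from compound 1 to compound 2 (1.85 log units; beyond the scatter) shows how far a single swap can move the number. For compound 4 the estimated value is 1500 nM, with an expected range from 300 nM to 7500 nM.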

Compound 4, half-maximal inhibitory concentration: > 10000 nM
Compound 4: no number, only a limit; the forecaster's own chance of this, stated with the estimate: 10%; middle value at least 6.6-fold (0.82 log units) from the limit.
By their numbers in this assay, from the lowest: compound 2; then compounds 3 and 1 (each within the scatter of the next). At a limit, above all of these: compound 4.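

In this assay, compound 4 gives no number, only a limit of the assay: the limit of > 10000 nM in this assay, at which 1 of the 4 values shown sits. Even so, the step is readable in one direction, with ethoxycarbonyl giving an at least 11-fold higher number from compound 3 to compound 4 (1.05 log units; beyond the scatter) and an at least 6.7-fold higher number from compound 1 to compound 4 (0.82 log units; beyond the scatter), so this position is more than a contrast between methyl and two groups that sit level with each other. A third level now appears on the weak side of chloro and vinyl. Set against methyl, the same group gives an at least 470-fold higher number from compound 2 to compound 4 (2.67 log units; beyond the scatter), the widest gap among the compounds shown, so a single swap at this aromatic carbon can span a far larger range than the earlier compounds revealed.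

How far the true value of compound 4 lies past its limit stays unknown, and the data give no reason why ethoxycarbonyl and methyl stand so far apart. As far as these compounds go, it also remains open whether an ethyl or a methoxy group here would go with compound 2 or with compounds 1 and 3, and whether a carboxylic acid or an amide would go with compound 4.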